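The source may hold more compounds than are shown below. What is called first, only, known or untested is meant among the compounds shown, and "the series" means these compounds.

Two compounds have been measured in an in vitro functional assay on HEK293-A cells for negative allosteric modulation of metabotropic glutamate receptor 5 (Homo sapiens), read by FLIPR and calcium flux; a lower number here means a stronger inhibitor, a higher number a weaker inhibitor:

compound 1 `O=C1CC(c2nc(-c3cccc(Cl)c3)no2)CN1c1ccc(Cl)cc1`: > 10000 nM
compound 2 `O=C1CC(c2nc(-c3cccc(Cl)c3)no2)CN1c1ccccc1Cl`: 680 nM

The value given for compound 1 in this assay is a limit of the assay, not a number, and compound 1 sits at the limit of > 10000 nM in this assay, at which 1 of the 2 values shown sits. Going by the values given here, compound 2 is a different matter: in this assay compound 2 gives 680 nM, and the single one-place step between them, an at least 14-fold lower number from compound 1 to compound 2 (1.16 log units; beyond the scatter), is large.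

Compound 3 `COc1cccc(N2CC(c3nc(-c4cccc(Cl)c4)no3)CC2=O)c1` has not yet been measured. It differs from compound 1 in one place: 3-methoxyphenyl in place of 4-chlorophenyl on an amide-type nitrogen in a ring. Among the compounds with values here, the only measured step that bears on this change is an at least 14-fold lower number from compound 1 to compound 2 (1.16 log units; beyond the scatter), which shows that exchanging the 4-chlorophenyl of compound 1 for another group on the same nitrogen can bring a large gain. The 3-methoxyphenyl of compound 3 is neither of the two measured groups, so the size of its effect is uncertain. The expectation is still a downward step, an at least 3.3-fold lower number from compound 1 to compound 3 (0.52 log units; beyond the scatter), with compound 3 expected to land at 3000 nM, somewhere between 500 nM and 10000 nM.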

Compound 3, half-maximal inhibitory concentration: 690 nM
Compound 3: middle estimate off by 4.3-fold (0.64 log units), on the high side; the range from low to high includes it.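

In this assay, a second replacement of the 4-chlorophenyl on the amide-type nitrogen gives another large step, an at least 14-fold lower number from compound 1 to compound 3 (1.16 log units; beyond the scatter), so the gain is no longer tied to one group: both 2-chlorophenyl and 3-methoxyphenyl provide it. These two replacements cannot be told apart in this assay, a 1.0-fold higher number from compound 2 to compound 3 (0.01 log units; within the scatter), although their names show that they carry different substituents at different ring positions. Among the three compounds, therefore, the 4-chlorophenyl of compound 1 is the one that stands apart, and the value of compound 1 is a limit of the assay, not a number: the limit of > 10000 nM in this assay, at which 1 of the 3 values shown sits.

The compounds shown leave open whether the loss in compound 1 follows the chlorine, its ring position or the combination of the two, a question that 4-methoxyphenyl and 3-chlorophenyl on the same nitrogen would help to separate. They also leave open whether the nitrogen needs a substituted ring at all, which plain phenyl would address, and whether larger gains lie with other groups such as 3-ethoxyphenyl or 3-cyanophenyl.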